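The source may hold more compounds than are shown below. What is called first, only, known or untested is meant among the compounds shown, and "the series" means these compounds.

Working notes on the series. Compound 1 `O=C(/C=C\Nc1ccc(Cl)cc1)c1cn(-c2ccccc2)nc1-c1ccc(F)cc1` and compound 2 `O=C(/C=C\Nc1ccc(C(F)(F)F)cc1)c1cn(-c2ccccc2)nc1-c1ccc(F)cc1` share one core and differ only on one aryl ring. In an ADME assay on HaCaT cells (Homo sapiens) for antiproliferative activity, read by MTT assay, with a stated time of 48 h (on this read-out higher numbers stand for weaker inhibition and lower numbers for stronger inhibition), compound 1 gives 21300 nM. For compound 2 the read-out in this assay is only a limit, > 50000 nM, and no number is available for compound 2. Compound 2 therefore stands at the limit of > 50000 nM in this assay, at which 1 of the 2 values shown sits. Going by the values given here, the single measured step, an at least 2.3-fold higher number from compound 1 to compound 2 (0.37 log units; beyond the scatter), runs into that limit and is known only as a lower bound on its size.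

Compound 3 `O=C(/C=C\Nc1ccc(C(F)(F)F)cc1)c1cn(-c2ccccc2)nc1-c1ccc(Cl)cc1` is the next member and is not yet measured. Against compound 2 the change is chloro in place of fluoro on an aromatic carbon. Among the compounds with values here, none of the measured steps touches this position: the one step on record, trifluoromethyl in place of chloro, sits on a different ring and does not inform a halogen swap here. The change exchanges one halogen for another, one heavy atom for one heavy atom, and on the numbers available there is no ground for a shift beyond the scatter in either direction. The expected step is a step that the limit leaves unreadable from compound 2 to compound 3, within the scatter. Compound 3 is thus estimated at 60000 nM in this assay, with a range from 25000 nM to 150000 nM, and most likely again reported only as a limit.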

Compound 3, half-maximal inhibitory concentration: > 50000 nM
Compound 3 was reported as a limit; the forecaster's own chance of this, stated with the estimate: 65%; the middle value does not contradict the limit.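

In this assay compound 3 gives > 50000 nM as a limit and not a number. Going by these compounds alone, compound 2 also stands at a limit, so no step from compound 2 to compound 3 can be read: the limit of > 50000 nM in this assay, at which 2 of the 3 values shown sit.

The compounds shown leave open whether 4-fluorophenyl to 4-chlorophenyl shifts the read-out in this assay at all.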